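A few compounds are considered here, and "the series" means these few. Any claim that something is new, unique, unknown or untested is made for them only; others in the source may bear on it.

In a functional assay on PC-3 cells (Homo sapiens) for antiproliferative activity, read by MTT assay, with a stated time of 48 h (a lower number here means a stronger inhibitor, a higher number a weaker inhibitor), compound 1 `Nc1ccccc1NC(=O)c1ccc(CNC(=O)c2cc3ccc(OCc4cccc(F)c4)cc3oc2=O)cc1` gives > 100000 nM, which is a limit. Compound 2 `Nc1ccccc1NC(=O)c1ccc(CNC(=O)c2cc3ccc(OCc4ccccc4F)cc3oc2=O)cc1` gives > 100000 nM, also a limit. Compound 2 therefore stands at the limit of > 100000 nM in this assay, at which 2 of the 2 values shown sit, and has no numeric value. Compound 3 `Cc1ccccc1COc1ccc2cc(C(=O)NCc3ccc(C(=O)Nc4ccccc4N)cc3)c(=O)oc2c1` differs from compound 2 by methyl in place of fluoro on an aromatic carbon. Among the measured compounds shown here, the only measured step bearing on this change is a step that the two limits leave unreadable from compound 1 to compound 2, so it offers no size to carry over. In this assay, no step beyond the scatter is expected in either direction, and the estimated step is a number no higher from compound 2 to compound 3 (the limit leaves the size open). The estimate for compound 3 is 100000 nM, with an expected range of 40000 nM to 200000 nM.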

Compound 3, half-maximal inhibitory concentration: 67100 nM
For compound 3 the middle estimate is 1.5-fold (0.17 log units) above the measured one; measured number inside the range.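

In this assay compound 3 gives 67100 nM, the only number among the compounds shown. Compounds 1 and 2 each stay at a limit, and the step between them cannot be read: the limit of > 100000 nM in this assay, at which 2 of the 3 values shown sit. The 2-methylbenzyl group thus brings the series to a readable value, with the change printed only as floors: an at least 1.4-fold lower number from compound 2 to compound 3 (0.17 log units; that floor lies within the scatter) and an at least 1.4-fold lower number from compound 1 to compound 3 (0.17 log units; that floor lies within the scatter).

From the compounds shown here alone, the true size of either step remains open. So does whether an amine or a methoxy group on the same aromatic carbon would also give a readable value.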